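This account rests on a few compounds, and the source may have more. Where it says the series, first, only, none or still open, it means among the compounds named here.

Of the compounds shown here, two sharing the same core have been measured so far in an ADME assay on a cell-free system (plasma, Homo sapiens) for metabolic stability, read by HPLC; a lower number here means that the compound disappears faster, a higher number that the compound lasts longer: compound 1 (`CCCC(CCC)C(=O)N(C)/N=N/c1ccc(C(N)=O)cc1`) and compound 2 (`CCCC(CCC)C(=O)N(C)/N=N/c1ccc(C(=O)OC)cc1`). Compound 1 gives > 40 h, which is a limit and not a number. Compound 2 gives > 40 h, which is also a limit. The evidence so far amounts to the limit of > 40 h in this assay, at which 2 of the 2 values shown sit. Compound 2 therefore has no exact half-life from which to count the next step.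

Compound 3 (`CCCC(CCC)C(=O)N(C)/N=N/c1ccc(C)cc1`) differs from compound 2 at a different place from the one changed earlier: methyl in place of methoxycarbonyl on an aromatic carbon. Within the data shown here, the only measured step is a step that the two limits leave unreadable from compound 1 to compound 2. That step has no readable size and concerns a swap on the carbonyl carbon, so it offers no size to carry over to methyl in place of methoxycarbonyl. No step beyond the scatter is expected in this assay, although a modest fall cannot be excluded. The estimated change is an at least 1.1-fold lower number from compound 2 to compound 3 (0.05 log units; that floor lies within the scatter). For compound 3 the expected half-life is 35 h, with an estimated range from 12 h to 80 h.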

Compound 3, half-life: > 40 h
Compound 3: no number, only a limit; the forecaster's own chance of this, stated with the estimate: 55%; middle value at least 1.1-fold (0.05 log units) from the limit.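

In this assay no step can be read among compound 1, compound 2 and compound 3, as each result is a limit and not a number: the limit of > 40 h in this assay, at which 3 of the 3 values shown sit. The compounds shown leave open the actual half-life of all three, and whether carbamoyl, methoxycarbonyl or methyl on the aromatic carbon makes any difference to it.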